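The compounds below may be only part of what the source reports. "The series", "measured", "known", "first", "only" and "open" are said of these compounds alone.

Working notes on the series: in a functional assay on SW-620 cells (Homo sapiens) for cytotoxicity, read by MTT assay, with stated times of 4 h and 72 h, tested at 2 uM (on this read-out higher numbers stand for weaker inhibition and lower numbers for stronger inhibition), compound 1 (`Cc1cc(Nc2ccc(C(=O)/C=C/c3ccccc3)cc2)n2nc(SCc3nc4ccccc4[nH]3)nc2n1`) gives 130 nM and compound 2 (`Cc1cc(Nc2ccc(C(=O)/C=C/c3ccc(-n4cccn4)cc3)cc2)n2nc(SCc3nc4ccccc4[nH]3)nc2n1`) gives 340 nM, so compound 2 holds the higher of the two numbers, meaning the weaker inhibition. Compound 3 (`Cc1cc(Nc2ccc(C(=O)/C=C/c3cccc(F)c3)cc2)n2nc(SCc3nc4ccccc4[nH]3)nc2n1`) is still unmeasured. Its difference from compound 2 is 3-fluorophenyl in place of 4-(1H-pyrazol-1-yl)phenyl on a double-bonded chain carbon bound to a double-bonded chain carbon. Among the compounds with values here, the only measured step that bears on this, a 2.6-fold higher number from compound 1 to compound 2 (0.42 log units; beyond the scatter), came with 1H-pyrazol-1-yl in place of hydrogen on an aromatic carbon and was modest, so a modest step of similar size towards a lower number is expected in this assay. Within the data shown here, no measured step covers the fluoro group, which widens the range. The expected move is a 2.1-fold lower number from compound 2 to compound 3 (0.33 log units; beyond the scatter). Compound 3 is estimated at 160 nM, with an expected range of 65 nM to 400 nM.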

Compound 3, half-maximal inhibitory concentration: 590 nM
Compound 3: middle estimate off by 3.7-fold (0.57 log units), on the low side; measured number outside the range, above it.
By their numbers in this assay, from the lowest: compound 1; then compounds 2 and 3 (each within the scatter of the next).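

Within this assay, this position has so far given no number lower than that of the unsubstituted phenyl of compound 1: fluoro in place of hydrogen on an aromatic carbon gives a 4.5-fold higher number from compound 1 to compound 3 (0.66 log units; beyond the scatter), so even this single-atom replacement is not neutral here. Exchanging 4-(1H-pyrazol-1-yl)phenyl for 3-fluorophenyl gives a 1.7-fold higher number from compound 2 to compound 3 (0.24 log units; within the scatter), so these two quite different groups cannot be told apart on this read-out. Both substituted compounds therefore lie on the same side of compound 1, with no exception among the three compounds.

As far as these compounds go, whether a hydroxyl group or an amine on this phenyl ring would also stay on that side remains open. So does whether the result for compound 3 belongs to fluoro as such or to its place on the ring, and nothing available explains the results.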